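The source may hold more compounds than are shown below. What is called first, only, known or untested is meant among the compounds shown, and "the series" means these compounds.

Of the compounds shown here, three have been measured in a physicochemical assay for lipophilicity, in phosphate buffer, measured as octanol-water partition, with a stated time of 24 h (a higher number here means a more lipophilic compound, a lower number a more polar compound), so far. Compound 1 `C(=N/Nc1nc2ccccc2s1)\c1ccc(Oc2ccc3ccccc3c2)cc1` gives 5.6, compound 2 `O=C(CSc1nc2ccccc2s1)N/N=C/c1ccc(Oc2ccc([N+](=O)[O-])cc2)cc1` gives 5.3, and compound 3 `Brc1ccc(Oc2ccc(/C=N/Nc3nc4ccccc4s3)cc2)cc1` gives 5.5. Compound 2 sits within the usual scatter of both neighbours: its distance to compound 3 and its distance to compound 1 both fall inside the spread of repeated measurements, so the three values cannot be ranked against each other.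

Compound 4 `Cc1cc(Oc2ccc(/C=N/NC(=O)CSc3nc4ccccc4s3)cc2)ccc1Cl` has not yet been measured in this assay. It differs from compound 2 in one place: 4-chloro-3-methylphenyl in place of 4-nitrophenyl on an oxygen on an aromatic ring.

Among the compounds with values here, no measured pair shows this exact change, so the expected step rests on the three values alone, which all lie close together despite differing aryl ends. A step upward from compound 2 to compound 4 is expected, slightly beyond the scatter, of size a number 0.60 log units higher from compound 2 to compound 4 (beyond the scatter). For compound 4 in this assay the estimate is 5.9, with a range from 5.4 to 6.4.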

Compound 4, partition coefficient: 5.7
Compound 4: the middle estimate sits 0.20 log units above what was measured; measured number inside the range.
By their numbers in this assay, from the lowest: compounds 2, 3, 1 and 4 (each within the scatter of the next, the first and the last beyond it).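

In this assay, within the data shown here, 4-chloro-3-methylphenyl in place of 4-nitrophenyl on an oxygen on an aromatic ring gives a number 0.40 log units higher from compound 2 to compound 4 (beyond the scatter) and is the first change in one place that can be read in this set. The earlier compounds shown here differed in more than one place and lay within the scatter of each other, so they showed nothing about this position alone; this pair shows that the aromatic group on this oxygen can move the number beyond the scatter, at least for this one exchange on this core. Nothing measured here accounts for the step.

The compounds shown leave open how much of the step goes with the chlorine and how much with the methyl. From the compounds shown here alone, it also remains open how an amine or a carboxylic acid on that aromatic ring would read in this assay on the same core.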